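The source may report more compounds than this note shows. Statements on the series, on what has been measured and on what is new or still open speak of the compounds shown alone.

Measured compounds:
compound 1 `COc1ccc(-c2cc(/C=C/C(=O)c3ccc(N)cc3)[nH]n2)cc1OC`: -58%
compound 2 `COc1ccc(-c2cc(/C=C/C(=O)c3cc(OC)c(OC)c(OC)c3)[nH]n2)cc1OC`: -43%
compound 3 `COc1ccc(C(=O)/C=C/c2cc(-c3cc(OC)c(OC)c(OC)c3)n[nH]2)cc1`: -69%

All three were tested in a functional assay on MCF7 cells (Homo sapiens) for cytotoxicity, read by sulforhodamine B assay, with a stated time of 48 h, tested at 100 uM; on this read-out higher numbers stand for a weaker effect at the one concentration tested and lower numbers for a stronger effect. On this read-out compound 3 gives the lowest number of the three, which here means the strongest effect: compound 1 gives a number higher than that of compound 3 by a gap beyond the scatter, and compound 2 gives a number higher still, also beyond the scatter. Compound 3 is thus the strongest of the three in this assay.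

Compound 4 `COc1cc(-c2cc(/C=C/C(=O)c3ccc(F)c(F)c3)[nH]n2)cc(OC)c1OC` has not yet been measured. It differs from compound 3 in one place: 3,4-difluorophenyl in place of 4-methoxyphenyl on a carbonyl carbon. Among the compounds with values here, no pair of measured compounds differs by this kind of change, so the data give no direct guide to its effect. A step of modest size toward a weaker effect is expected from compound 3 to compound 4, a number 19 percentage points higher from compound 3 to compound 4 (beyond the scatter), but a step within the scatter would not be surprising. Compound 4 is expected to give about -50% in this assay, somewhere between -80% and -20%.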

Compound 4, a percentage reported as activity, at one concentration (the size of the read-out at that concentration, not a potency): -20%
Estimate against measurement, compound 4: 30 percentage points below; the range from low to high includes it.
By their numbers in this assay, from the lowest: compound 3; then compound 1; then compound 2; then compound 4.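

In this assay, the group on a carbonyl carbon proves able to change the result on its own: 3,4-difluorophenyl in place of 4-methoxyphenyl gives a large step toward a weaker effect, a number 49 percentage points higher from compound 3 to compound 4 (beyond the scatter). The earlier compounds shown here included no pair differing in one place, so they could not separate the effect of this group from that of the rest of the structure. The data offer no explanation for why this change weakens the effect.

This single swap removes a methoxy group and adds two fluorines at once, so it cannot show which part of the change matters, and a plain phenyl or a 4-fluorophenyl at the same place would help to separate them. As far as these compounds go, it also remains open whether a 4-hydroxyphenyl there would keep the effect of compound 3.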